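Mirror Images and a Partly Inverted Third Compound

A few compounds are considered here, and "the series" means these few. Any claim that something is new, unique, unknown or untested is made for them only; others in the source may bear on it.

In a functional assay on SBC-5 cells (Homo sapiens) for inhibition (on this read-out higher numbers stand for weaker inhibition and lower numbers for stronger inhibition), compound 1 (`C=C(C)CCC[C@]1(C)CCC[C@@H]2C1=CC[C@@H](C)[C@@]2(C)C[C@@H](O)C1=CC(=O)O[C@H]1O`) gives 5400 nM, while its mirror image, compound 2 (`C=C(C)CCC[C@@]1(C)CCC[C@H]2C1=CC[C@H](C)[C@]2(C)C[C@H](O)C1=CC(=O)O[C@@H]1O`), gives 16000 nM. Compound 2 therefore holds the higher of the two numbers, which means the weaker inhibition. For the measured compounds named here, the only measured step, a 3.0-fold higher number from compound 1 to compound 2 (0.47 log units; beyond the scatter), is modest but beyond the usual scatter, and the gap exists because of the fact that compounds 1 and 2 differ only in the configuration as drawn.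

The next compound, compound 3 (`C=C(C)CCC[C@]1(C)CCC[C@@H]2C1=CC[C@@H](C)[C@]2(C)C[C@H](O)C1=CC(=O)OC1O`), keeps the same atoms and bonds and changes only in how its stereocentres are drawn: the two compounds have the same atoms and bonds; at least one stereo element is drawn with a configuration in one of them and without one in the other: 4 of 6 stereo elements differ; a stereocentre at a saturated ring carbon is drawn R in compound 2 and S in compound 3; a stereocentre at a saturated ring carbon is drawn R in compound 2 and S in compound 3; a stereocentre at a saturated ring carbon is drawn S in compound 2 and R in compound 3; a stereocentre at a saturated ring carbon is drawn S in compound 2 and without a configuration in compound 3. One of those stereocentres, at a saturated ring carbon, has no drawn configuration in compound 3, so the sample may not match a single drawn form.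

Going by the values given here, the measured step between compounds 1 and 2 is the only guide, and it involved configuration alone. With compound 2 at the top of the range so far, a modest move toward stronger inhibition seems most likely, no larger than that measured step. In this assay, the estimated change is a 1.8-fold lower number from compound 2 to compound 3 (0.25 log units; within the scatter). For compound 3, the expected value is 9000 nM, with an estimated range from 3500 nM to 22000 nM.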

Compound 3, half-maximal inhibitory concentration: 1300 nM
Beside the measured number, compound 3's estimate is 6.9-fold (0.84 log units) above it; measured number outside the range, below it.
By their numbers in this assay, from the lowest: compound 3; then compound 1; then compound 2.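

Compound 3 now holds the lowest number in this assay, and both of its steps lie beyond the scatter: a 12-fold lower number from compound 2 to compound 3 (1.09 log units; beyond the scatter), and a 4.2-fold lower number from compound 1 to compound 3 (0.62 log units; beyond the scatter). The mirror-image pair therefore did not mark the limits of what configuration can do here: with atoms and bonds unchanged, a compound that departs from compound 1 at 3 of 6 stereo elements inhibits more strongly than either mirror image. Neither step can be pinned on a single stereocentre, because several centres change together and one of them has no drawn configuration in compound 3: the fact that one of compounds 1 and 3 is drawn with a defined configuration and the other without, at the place where they differ

The compounds shown leave open which of the changed stereocentres carries the gain, and whether the sample of compound 3 is one form or a mixture at its undrawn centre. All three compounds share the same atoms and bonds, so they also leave open how the number would respond to a new group on the shared core, such as an amine or a carboxylic acid.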